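Swapping Fluoro for Methoxy on a Weak Inhibitor

A few compounds are considered here, and "the series" means these few. Any claim that something is new, unique, unknown or untested is made for them only; others in the source may bear on it.

Of the compounds shown here, three built on one shared core have been tested in a functional assay on MCF7 cells (Homo sapiens) for antiproliferative activity, read by sulforhodamine B assay, with a stated time of 72 h; a higher number here means a weaker inhibitor, a lower number a stronger inhibitor. Compound 1 `COc1ncc(-c2ccc3ncnc(Nc4ccc(OCCO)c(F)c4)c3c2)cc1NS(=O)(=O)c1ccc(F)cc1F` gives 4820 nM in this assay. Compound 2 `COc1ncc(-c2ccc3ncnc(Nc4cnn(CCCO)c4)c3c2)cc1NS(C)(=O)=O` gives 730 nM in this assay. For compound 3 `CCCCS(=O)(=O)Nc1cc(-c2ccc3ncnc(Nc4ccc(OCCO)nc4)c3c2)cnc1OC` this assay reports only a limit, > 20000 nM, and not a number. Of the two plain numbers, compound 1 stands as the higher, with compound 2 the nearer figure and the gap between them beyond the usual scatter. Among the measured compounds shown here, no pair of measured compounds differs in just one place, so no measured single step is available for guidance.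

Compound 4 `COc1cc(Nc2ncnc3ccc(-c4cnc(OC)c(NS(=O)(=O)c5ccc(F)cc5F)c4)cc23)ccc1OCCO` has not been measured in this assay. It differs from compound 1 in one spot: methoxy in place of fluoro on an aromatic carbon.

For the measured compounds named here, with no measured step of this kind to lean on, the step from compound 1 to compound 4 is expected to be small, within the scatter or barely beyond it, in no settled direction: a 1.0-fold higher number from compound 1 to compound 4 (0.02 log units; within the scatter). Compound 4 is thus expected to give about 5000 nM in this assay, within a range from 1500 nM to 16000 nM.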

Compound 4, half-maximal inhibitory concentration: 2260 nM
Compound 4: middle estimate off by 2.2-fold (0.34 log units), on the high side; the measured number falls inside the stated range.
By their numbers in this assay, from the lowest: compound 2; then compound 4; then compound 1. At a limit, above all of these: compound 3.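

In this assay, placing methoxy instead of fluoro on the aromatic carbon ortho to the 2-hydroxyethoxy group gives a 2.1-fold lower number from compound 1 to compound 4 (0.33 log units; beyond the scatter). This first single-place step shows that the position accepts the larger methoxy group, which adds one hydrogen-bond acceptor by count, with no loss of activity and a modest gain. Nothing measured here accounts for the size or direction of this step.

Going by these compounds, how a chloro group, an amine or a longer ethoxy chain would compare at this position remains open. It is also unknown whether the same swap would give a similar step elsewhere, since this single pair rests on the rest of compound 1 alone.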